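This account rests on a few compounds, and the source may have more. Where it says the series, first, only, none or still open, it means among the compounds named here.

Compound 1 `Cc1ccc2nc(N3CCCc4ccc(F)cc4C3)cc(NCC(C)N)c2c1` gives 86000 nM in an ADME assay on HEp-2 cells (Homo sapiens) for cytotoxicity, read by CCK-8 assay, with a stated time of 5 days; on this read-out higher numbers stand for lower toxicity in this test and lower numbers for higher toxicity in this test. Compound 2 `Cc1ccc2nc(N3CCCc4ccc(F)cc4C3)cc(NC(C)(C)CN)c2c1` gives 25000 nM, and compound 3 `Cc1ccc2nc(N3CCCc4ccc(F)cc4C3)cc(NCC(C)(C)N)c2c1` gives 23000 nM. Compound 3 holds the lowest of the three numbers; its gap to compound 2 is within the scatter, while the step of a 3.7-fold lower number from compound 1 to compound 3 (0.57 log units; beyond the scatter) lies beyond it. Compound 4 `CC(=O)NCCNc1cc(N2CCCc3ccc(F)cc3C2)nc2ccc(C)cc12` differs from compound 3 by acetamidomethyl in place of 1-amino-1-methylethyl on a saturated chain carbon bound to a nitrogen on an aromatic ring. Among the measured compounds shown here, no measured step makes this exact change. The step of a 3.7-fold lower number from compound 1 to compound 3 (0.57 log units; beyond the scatter) added a methyl at that carbon and is partly undone here, and the step of a 1.1-fold lower number from compound 2 to compound 3 (0.04 log units; within the scatter) shows that moving the methyls barely registers. A modest rise in the number is therefore expected, a 2.2-fold higher number from compound 3 to compound 4 (0.34 log units; beyond the scatter), so compound 4 is estimated at 50000 nM, within 15000 nM to 150000 nM.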

Compound 4, half-maximal cytotoxic concentration: 66000 nM
The estimate for compound 4 lay 1.3-fold (0.12 log units) below the measured number; low and high end bracket the measured number.
By their numbers in this assay, from the lowest: compounds 3 and 2 (each within the scatter of the next); then compounds 4 and 1 (each within the scatter of the next).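

In this assay, 2-acetamidoethyl on the nitrogen on the aromatic ring separates from both dimethyl-bearing chains, with a 2.9-fold higher number from compound 3 to compound 4 (0.46 log units; beyond the scatter) and a 2.6-fold higher number from compound 2 to compound 4 (0.42 log units; beyond the scatter). Against the 2-aminopropyl chain, a 1.3-fold lower number from compound 1 to compound 4 (0.11 log units; within the scatter) leaves no distinction, so an acetamide at this position fits within the range already spanned by the free amines. No available evidence bears on the origin of these steps.

Still open, from the compounds shown here alone, is how much of the rise belongs to the acetyl group and how much to the missing methyls. A plain 2-aminoethyl chain would separate the two, and a longer acetamide chain would test the chain length.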